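Bromo for Fluoro on a Thiourea Pair

A few compounds are considered here, and "the series" means these few. Any claim that something is new, unique, unknown or untested is made for them only; others in the source may bear on it.

Measured compounds:
compound 1, `Fc1ccccc1NC(=S)Nc1cccc(C(F)(F)F)c1`: 64000 nM
compound 2, `O=C(NC(=S)Nc1cccc(C(F)(F)F)c1)[C@H]1C[C@@H]2CC[C@H]1C2`: 20000 nM
compound 3, `Fc1ccc(NC(=S)Nc2cccc(C(F)(F)F)c2)cc1Cl`: 20000 nM

These three thioureas were tested in an ADME assay on Vero 76 cells (Chlorocebus sabaeus) for cytotoxicity, read by crystal violet staining, with a stated time of 96 h; on this read-out lower numbers stand for higher toxicity in this test and higher numbers for lower toxicity in this test. Compound 1 stands highest of the three numbers, so it is the least toxic here; compound 2 and compound 3 both sit at lower numbers, and each gap to compound 1 lies beyond the usual scatter. No two of the measured compounds differ in only one place, so nothing directly tells how a single swap moves this read-out.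

Compound 4, `FC(F)(F)c1cccc(NC(=S)Nc2ccccc2Br)c1`, differs from compound 1 by bromo in place of fluoro on an aromatic carbon. Among the measured compounds shown here, with no matching step among the measured compounds, the expectation is a small move toward a lower number, or none beyond the scatter, as a 1.6-fold lower number from compound 1 to compound 4 (0.20 log units; within the scatter). Compound 4 is estimated at 40000 nM, with a range from 15000 nM to 100000 nM.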

Compound 4, half-maximal cytotoxic concentration: 50000 nM
Compound 4: middle estimate off by 1.3-fold (0.10 log units), on the low side; the range from low to high includes it.
By their numbers in this assay, from the lowest: compounds 2 and 3 (each within the scatter of the next); then compounds 4 and 1 (each within the scatter of the next).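

Among the compounds shown here, this gives the first comparison here in which only one place changes. In this assay bromo in place of fluoro on an aromatic carbon, ortho to a large group, gives a 1.3-fold lower number from compound 1 to compound 4 (0.11 log units; within the scatter) and so leaves the read-out unchanged within the usual scatter. At this position, the test does not separate these two halogens, and no measured evidence explains the result.

Going by these compounds, whether a different kind of group here, such as an amine or a carboxylic acid, would shift the number remains open. So does whether this swap would behave alike elsewhere on the ring.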